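The source may report more compounds than this note shows. Statements on the series, on what has been measured and on what is new or still open speak of the compounds shown alone.

Measured so far in a functional assay on the whole organism (strain Icem-CET (SPF Caw)) for inhibition, with Mus musculus as the target, with a stated time of 30 min; on this read-out lower numbers stand for an effect already at smaller amounts and higher numbers for an effect only at larger amounts of compound:
compound 1 `C#CCNC(=O)/C(C)=C(\C)c1ccc(Br)cc1` — 18.4 mg/kg
compound 2 `C=CCNC(=O)/C(C)=C(\C)c1ccc(Br)cc1` — 33.7 mg/kg
compound 3 `C#CCNC(=O)/C(C)=C(\C)c1ccc(OC)cc1` — 112 mg/kg

Compound 3 stands at the highest number of the three, beyond the scatter from both others; the nearest is compound 2 and the furthest compound 1. The change to compound 4 `C#CCNC(=O)/C(C)=C(\C)c1ccc(Cl)cc1` is chloro in place of methoxy on an aromatic carbon. Among the compounds with values here, the one measured step that bears on this is a 6.1-fold higher number from compound 1 to compound 3 (0.78 log units; beyond the scatter), which replaces bromo by methoxy at the same aromatic carbon and moves the number up by a modest amount. The step to compound 4 runs the other way, from methoxy back to a single-heavy-atom group with no hydrogen-bond acceptor, as bromo in compound 1 is. The other step, a 1.8-fold higher number from compound 1 to compound 2 (0.26 log units; within the scatter), concerns the chain on the amide nitrogen and is within the scatter, so it says nothing about this change. A downward step in this assay is therefore expected, of roughly the size seen between the bromo and methoxy compounds. Compound 4 is estimated at 25 mg/kg, with a range from 12 mg/kg to 60 mg/kg. The estimated step is a 4.5-fold lower number from compound 3 to compound 4 (0.65 log units; beyond the scatter).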

Compound 4, dose for half-maximal effect: 10.6 mg/kg
Beside the measured number, compound 4's estimate is 2.4-fold (0.37 log units) above it, outside the stated range (below it).
By their numbers in this assay, from the lowest: compounds 4, 1 and 2 (each within the scatter of the next, the first and the last beyond it); then compound 3.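

At this aromatic carbon, para to a large group, this assay gives an 11-fold lower number from compound 3 to compound 4 (1.02 log units; beyond the scatter), so the change from methoxy to chloro is a large one. With a 1.7-fold lower number from compound 1 to compound 4 (0.24 log units; within the scatter) inside the scatter, chloro and bromo cannot be told apart here, and among the compounds sharing the ethynyl-bearing chain, the two halogen compounds stand together, with methoxy compound 3 apart at the higher number. No measurement at hand accounts for this difference between methoxy and the halogens.

Still open, on these data alone, is whether fluoro, trifluoromethyl, nitrile or an amine at this carbon would sit with the halogens or with methoxy. Also open, as far as these compounds go, is whether chloro and bromo stay indistinguishable when the chain on the amide nitrogen is changed, as in compound 2, or replaced by a longer chain.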